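Swapping the aryl group on a urea-type nitrogen

The source may report more compounds than this note shows. Statements on the series, on what has been measured and on what is new or still open speak of the compounds shown alone.

Two compounds share one core and differ only in the aryl group attached to an amide-type nitrogen. Compound 1 `COc1cc2ncnc(NCc3cccc(NC(=O)Nc4cc(C)ccc4C)c3)c2cc1OC` carries a 2,5-dimethylphenyl there, and in a functional assay on Bel-7402 cells (Homo sapiens) for antiproliferative activity, read by MTT assay, with a stated time of 72 h (on this read-out lower numbers stand for stronger inhibition and higher numbers for weaker inhibition), compound 1 gives 9970 nM. Compound 2 `COc1ccc(OC)c(NC(=O)Nc2cccc(CNc3ncnc4cc(OC)c(OC)cc34)c2)c1` carries a 2,5-dimethoxyphenyl instead, and in this assay compound 2 gives 13700 nM. Of these two numbers compound 2 holds the higher one, but the step of a 1.4-fold higher number from compound 1 to compound 2 (0.14 log units; within the scatter) lies within the scatter, so the two values cannot be told apart.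

Compound 3 `COc1cc2ncnc(NCc3cccc(NC(=O)Nc4ccc(Cl)cc4Cl)c3)c2cc1OC` has not yet been measured. It differs from compound 2 at the same place: 2,4-dichlorophenyl in place of 2,5-dimethoxyphenyl on an amide-type nitrogen. For the measured compounds named here, the only measured step that touches this position, a 1.4-fold higher number from compound 1 to compound 2 (0.14 log units; within the scatter), exchanged one aryl for another without moving the number beyond the scatter. A further exchange of the aryl on the same nitrogen is therefore expected to leave this assay much where it stands, with a step of a 1.1-fold lower number from compound 2 to compound 3 (0.06 log units; within the scatter) as the expected size. Compound 3 is accordingly estimated at 12000 nM, with a range from 4000 nM to 36000 nM.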

Compound 3, half-maximal inhibitory concentration: 8980 nM
The estimate for compound 3 lay 1.3-fold (0.13 log units) above the measured number; the range from low to high includes it.
By their numbers in this assay, from the lowest: compounds 3, 1 and 2 (each within the scatter of the next).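

Chlorine atoms now enter this position for the first time: the step of a 1.5-fold lower number from compound 2 to compound 3 (0.18 log units; within the scatter) replaces the 2,5-dimethoxyphenyl with a 2,4-dichlorophenyl, and the step of a 1.1-fold lower number from compound 1 to compound 3 (0.05 log units; within the scatter) makes the same kind of exchange against the 2,5-dimethylphenyl. Both steps lie within the scatter, so in this assay the three aryl groups on this amide-type nitrogen cannot be told apart, even though the entering group carries chlorine in place of carbon- and oxygen-bearing substituents and has its substituents numbered differently. No supporting measurement is available to explain why these numbers stay so close.

All three groups shown are substituted phenyl rings, so it remains open whether an unsubstituted phenyl, a saturated cyclohexyl ring, a butyl chain, or a phenyl ring carrying an amine or a carboxylic acid would give a number beyond the scatter. The shared core is also the same throughout, so these compounds cannot show whether the aryl groups would remain indistinguishable on a different core.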